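From Phenyl to 4-Fluorophenyl in Compound 2

A few compounds are considered here, and "the series" means these few. Any claim that something is new, unique, unknown or untested is made for them only; others in the source may bear on it.

In a functional assay on the whole organism for inhibition, with Mus musculus as the target (on this read-out higher numbers stand for an effect only at larger amounts of compound and lower numbers for an effect already at smaller amounts), compound 1 `CCNC(=O)Nc1cccc2c1CN(C)CC2c1ccccc1` gives 80 mg/kg, while compound 2 `CCOC(=O)Nc1cccc2c1CN(C)CC2c1ccccc1` gives 3.2 mg/kg. Compound 2 therefore holds the lower of the two numbers. Among the compounds with values here, the only measured step is large and beyond the scatter: a 25-fold lower number from compound 1 to compound 2 (1.40 log units; beyond the scatter), with ethoxy in place of ethylamino on a carbonyl carbon.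

Compound 3 `CCOC(=O)Nc1cccc2c1CN(C)CC2c1ccc(F)cc1` keeps the ethoxy group and differs from compound 2 in one place: fluoro in place of hydrogen on an aromatic carbon. In short, the phenyl of compound 2 becomes a 4-fluorophenyl in compound 3.

The measured step bears on this change only weakly, since it lies at the carbonyl carbon and not on the phenyl. Within the data shown here, its size cannot be carried over, and no measured pair shows a change at the new place. Starting from compound 2 at 3.2 mg/kg, no step beyond the scatter is therefore expected in this assay, and neither direction is favoured. The estimated step is a 1.1-fold lower number from compound 2 to compound 3 (0.03 log units; within the scatter). For compound 3 the expected value is 3 mg/kg, with an estimated range of 1.2 mg/kg to 8 mg/kg.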

Compound 3, dose for half-maximal effect: 3.5 mg/kg
The estimate for compound 3 lay 1.2-fold (0.07 log units) below the measured number; low and high end bracket the measured number.
By their numbers in this assay, from the lowest: compounds 2 and 3 (each within the scatter of the next); then compound 1.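

In this assay, fluoro in place of hydrogen on an aromatic carbon, para to a large group, gives a 1.1-fold higher number from compound 2 to compound 3 (0.04 log units; within the scatter), so the numbers for these two compounds cannot be told apart. Within the data shown here, the earlier compounds varied only the group on the carbonyl carbon, and this pair is the first to give a reading at the phenyl: with the ethoxy group in place, going from phenyl to 4-fluorophenyl leaves no step beyond the scatter, unlike the large step of a 25-fold lower number from compound 1 to compound 2 (1.40 log units; beyond the scatter) at the carbonyl carbon. No supporting data on the compounds bear on why the numbers of this pair stand so close, and the result itself offers no explanation.

The compounds shown leave open whether a larger or differently built group at this same place, such as chloro, methoxy, trifluoromethyl or an amine, would also stay within the scatter of compound 2. They also leave open whether fluoro would give the same result on another carbon of this ring, or on the ring of compound 1, which carries the ethylamino group on its carbonyl carbon.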